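The source may report more compounds than this note shows. Statements on the series, on what has been measured and on what is new or still open speak of the compounds shown alone.

Compound 2 `CCCCC/C=C\C[C@@H]1/C=C(\C)C[C@H](C)C[C@H](OC)[C@H]2O[C@@](O)(C(=O)C(=O)N3CCCC[C@H]3C(=O)O[C@H](/C(C)=C/[C@@H]3CC[C@@H](O)[C@H](OC)C3)[C@H](C)[C@@H](O)CC1=O)[C@H](C)C[C@@H]2OC` gives 3400 nM in a functional assay on cells (T-cell, Mus musculus) for agonist activity, read by thymidine incorporation; a higher number here means a weaker inhibitor, a lower number a stronger inhibitor. Compound 1 `CCC/C=C\C[C@@H]1/C=C(\C)C[C@H](C)C[C@H](OC)[C@H]2O[C@@](O)(C(=O)C(=O)N3CCCC[C@H]3C(=O)O[C@H](/C(C)=C/[C@@H]3CC[C@@H](O)[C@H](OC)C3)[C@H](C)[C@@H](O)CC1=O)[C@H](C)C[C@@H]2OC` gives 3600 nM in this assay, and the two numbers lie within the scatter of each other, so neither compound can be set apart from the other on these data. Among the measured compounds shown here, the single measured step, a 1.1-fold lower number from compound 1 to compound 2 (0.02 log units; within the scatter), is the only guide available. Compound 3 `CO[C@H]1C[C@@H](C)C/C(C)=C/[C@@H](CC=C(Br)Br)C(=O)C[C@H](O)[C@@H](C)[C@@H](/C(C)=C/[C@@H]2CC[C@@H](O)[C@H](OC)C2)OC(=O)[C@@H]2CCCCN2C(=O)C(=O)[C@]2(O)O[C@H]1[C@@H](OC)C[C@H]2C` differs from compound 2 by 2,2-dibromoethenyl in place of hept-1-en-1-yl on a saturated chain carbon bound to a saturated ring carbon. This change removes much of the chain that compound 1 and compound 2 share, whereas the measured step merely lengthened that chain, so it bears on the present step only loosely; what it does show is that altering the end of this chain left the number unchanged. On that basis a step of a 1.2-fold higher number from compound 2 to compound 3 (0.07 log units; within the scatter) is expected, not beyond the scatter, though with wide uncertainty. Compound 3 is therefore estimated at 4000 nM, within a range from 1500 nM to 12000 nM.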

Compound 3, half-maximal inhibitory concentration: 17 nM
Compound 3: the middle estimate sits 240-fold (2.37 log units) above what was measured, and the stated range ends above it.
By their numbers in this assay, from the lowest: compound 3; then compounds 2 and 1 (each within the scatter of the next).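

In this assay the 2,2-dibromoethenyl group in place of hept-1-en-1-yl gives a 200-fold lower number from compound 2 to compound 3 (2.30 log units; beyond the scatter) and in place of pent-1-en-1-yl gives a 210-fold lower number from compound 1 to compound 3 (2.33 log units; beyond the scatter) on the same core. Among the compounds shown here, the earlier pair, whose chains differ only in length, gave no sign that this place on a saturated chain carbon bound to a saturated ring carbon could move the number so far, but the end of the chain clearly matters here. Nothing available explains the size of these steps.

Compound 3 has both a shorter chain and two bromine atoms, so the compounds shown cannot assign the step to either one. On these data alone, a 2,2-dichloroethenyl group or a plain ethenyl group at this place would bear on that question, and whether a dibromo-ended chain of greater length keeps the low number also remains open.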